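This account rests on a few compounds, and the source may have more. Where it says the series, first, only, none or still open, it means among the compounds named here.

The series shares one core, varied only at a single position on the pendant aromatic ring. Compound 1 `Cn1c(=O)c(=O)n(C2CCCC2)c2nc(N/N=C/c3ccc(O)cc3)ncc21` carries a hydroxy group there; in a functional assay on PC-3 cells (Homo sapiens) for antiproliferative activity, read by MTT assay (a higher number here means a weaker inhibitor, a lower number a stronger inhibitor), compound 1 reaches only the assay limit, > 100000 nM. Compound 2 `COc1ccc(/C=N/Nc2ncc3c(n2)n(C2CCCC2)c(=O)c(=O)n3C)cc1` carries a methoxy group, and in this assay compound 2 gives 26300 nM. Compound 3 `CSc1ccc(/C=N/Nc2ncc3c(n2)n(C2CCCC2)c(=O)c(=O)n3C)cc1` carries a methylsulfanyl group, and in this assay compound 3 gives 21000 nM. Among the two numbers available, compound 3 holds the lowest, with compound 2 sitting within the scatter of it; the value of compound 1 is a limit and not a number, the only such case here (the limit of > 100000 nM in this assay, at which 1 of the 3 values shown sits).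

Compound 4 `Cn1c(=O)c(=O)n(C2CCCC2)c2nc(N/N=C/c3ccc(OC(F)(F)F)cc3)ncc21` differs from compound 3 by trifluoromethoxy in place of methylsulfanyl on an aromatic carbon. The measured steps that bear on this are the exchange of one small para-substituent for another: an at least 3.8-fold lower number from compound 1 to compound 2 (0.58 log units; beyond the scatter) and an at least 4.7-fold lower number from compound 1 to compound 3 (0.67 log units; beyond the scatter) show that leaving the hydroxy compound brings a clear gain, whereas a 1.3-fold lower number from compound 2 to compound 3 (0.10 log units; within the scatter) shows that swapping methoxy for methylsulfanyl changes little. By analogy, replacing methylsulfanyl with trifluoromethoxy is expected to produce at most a small step, a 1.0-fold higher number from compound 3 to compound 4 (0.02 log units; within the scatter), in this assay. Compound 4 is therefore estimated at 22000 nM, within a range from 8000 nM to 65000 nM.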

Compound 4, half-maximal inhibitory concentration: 7180 nM
For compound 4 the middle estimate is 3.1-fold (0.49 log units) above the measured one, and the stated range ends above it.
By their numbers in this assay, from the lowest: compound 4; then compounds 3 and 2 (each within the scatter of the next). At a limit, above all of these: compound 1.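

In this assay, the change to trifluoromethoxy gives a 2.9-fold lower number from compound 3 to compound 4 (0.47 log units; beyond the scatter), and it also gives a 3.7-fold lower number from compound 2 to compound 4 (0.56 log units; beyond the scatter), so this position does respond among the groups that lack the hydroxy hydrogen, although the exchange of methoxy for methylsulfanyl had stayed within the scatter. The second of these steps keeps the oxygen on the ring and alters only the group on it, trifluoromethyl in place of methyl, which shows that a change beyond that oxygen is enough to move the number and makes compound 4 the strongest of the four compounds shown. The widest step, an at least 13-fold lower number from compound 1 to compound 4 (1.14 log units; beyond the scatter), rests on compound 1, whose value is a limit and not a number: the limit of > 100000 nM in this assay, at which 1 of the 4 values shown sits.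

The compounds shown leave open whether the oxygen is needed for this gain, as a trifluoromethyl group bonded directly to the ring, a chlorine or a nitrile could give a similar number or a different one. They also leave open how an amine, a carboxylic acid or a longer chain such as ethoxy would fare at this position.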